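Replacing the Octyl Chain with a Bromobenzyl Group

The source may hold more compounds than are shown below. What is called first, only, known or untested is meant among the compounds shown, and "the series" means these compounds.

Measured so far:
compound 1 `O=C(CBr)Nc1ccc(C(=O)/C=C/c2cn(Cc3ccc(Br)cc3)nn2)cc1` — 8670 nM
compound 2 `CCCCCCCCn1cc(/C=C/C(=O)c2ccc(N)cc2)nn1` — 26900 nM

Compound 2 stands at the highest of the two numbers in a functional assay on A549 cells (Homo sapiens) for inhibition, read by MTT assay; on this read-out higher numbers stand for weaker inhibition and lower numbers for stronger inhibition; compound 1 sits at a lower number, a gap beyond the scatter. Compound 3 `Nc1ccc(C(=O)/C=C/c2cn(Cc3ccc(Br)cc3)nn2)cc1` has not been measured. It differs from compound 2 by 4-bromophenyl in place of heptyl on a saturated chain carbon bound to an aromatic nitrogen. Within the data shown here, compound 1 carries the same 4-bromophenyl group, but its other substituent also differs, so no step is known for this change alone. The step of a 2.1-fold lower number from compound 2 to compound 3 (0.32 log units; beyond the scatter) is expected to be modest and downward. Compound 3 is estimated at 13000 nM, between 4500 nM and 38000 nM.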

Compound 3, half-maximal inhibitory concentration: 15800 nM
The estimate for compound 3 lay 1.2-fold (0.08 log units) below the measured number; measured number inside the range.
By their numbers in this assay, from the lowest: compounds 1, 3 and 2 (each within the scatter of the next, the first and the last beyond it).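

In this assay, octyl to 4-bromobenzyl on a saturated chain carbon bound to an aromatic nitrogen gives a 1.7-fold lower number from compound 2 to compound 3 (0.23 log units; within the scatter) and so cannot be told apart from the chain. Hydrogen in place of (bromomethyl)carbonyl on a nitrogen on an aromatic ring gives a 1.8-fold higher number from compound 1 to compound 3 (0.26 log units; within the scatter) and is equally unresolved, so neither single change alone separates its pair. No measurement at hand accounts for these results.

From the compounds shown here alone, a plain benzyl or a shorter butyl chain at this position remains open. So does an acetyl on that nitrogen.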